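Series notes: aryl carbonyl variation on the shared core

The source may hold more compounds than are shown below. What is called first, only, known or untested is meant among the compounds shown, and "the series" means these compounds.

Three compounds of the series carry a measured number in an ADME assay on a cell-free system (plasma, Homo sapiens) for metabolic stability, with Plasma (Rattus norvegicus) as the target, read by HPLC, at pH 7.4; on this read-out higher numbers stand for a longer-lived compound and lower numbers for a shorter-lived compound. Compound 1 `CC(=O)Oc1ccccc1C(=O)O[C@H]1CO[C@H]2[C@@H]1OC[C@H]2OC(=O)c1snnc1C` gives 0.0065 h in this assay. Compound 2 `CC(=O)Oc1ccccc1C(=O)O[C@H]1CO[C@H]2[C@@H]1OC[C@H]2OC(=O)c1cccc(C)c1` gives 0.0203 h in this assay, and compound 3 `CC(=O)Oc1ccccc1C(=O)O[C@H]1CO[C@H]2[C@@H]1OC[C@H]2OC(=O)c1ccccc1OC(=O)c1ccccc1` gives 0.0722 h in this assay. Compound 2 thus stands second highest of the three; the values of compound 2 and compound 3 show a gap that is beyond the scatter, with compound 3 the higher of the two.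

One measured step connects neighbours that differ in one place: a 3.1-fold higher number from compound 1 to compound 2 (0.49 log units; beyond the scatter). For the measured compounds named here, this is the only step that bears on the move to compound 4 `CC(=O)Oc1ccccc1C(=O)O[C@H]1CO[C@H]2[C@@H]1OC[C@H]2OC(=O)c1cc(C)nc(Cl)c1`, which differs from compound 2 as follows: 2-chloro-6-methylpyridin-4-yl in place of 3-methylphenyl on a carbonyl carbon. Both changes sit on the same carbonyl carbon and exchange the group attached there, so the step from compound 1 to compound 2 gives the scale to expect, though its direction cannot simply be carried over. A modest step, either way, is the most that the data support, and a lowering towards compound 1 is taken as somewhat more likely. For compound 4 the expected step is a 1.7-fold lower number from compound 2 to compound 4 (0.23 log units; within the scatter), and the value is estimated at 0.012 h, within 0.004 h to 0.04 h.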

Compound 4, half-life: 0.0193 h
The estimate for compound 4 lay 1.6-fold (0.21 log units) below the measured number; measured number inside the range.
By their numbers in this assay, from the lowest: compound 1; then compounds 4 and 2 (each within the scatter of the next); then compound 3.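

Working notes on the position: on this carbonyl carbon, in this assay, 2-chloro-6-methylpyridin-4-yl replaces 3-methylphenyl with a 1.1-fold lower number from compound 2 to compound 4 (0.02 log units; within the scatter), so a ring nitrogen and a chlorine enter together without a readable shift, which the earlier compounds had not tested. The step of a 3.0-fold higher number from compound 1 to compound 4 (0.47 log units; beyond the scatter) now stands alongside a 3.1-fold higher number from compound 1 to compound 2 (0.49 log units; beyond the scatter), so two different six-membered aromatic rings each lie beyond the scatter from the 4-methyl-1,2,3-thiadiazol-5-yl of compound 1, a separation that until now rested on compound 2 alone. No supporting measurement accompanies these numbers to account for either the unchanged reading or the separation from compound 1.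

From the compounds shown here alone, the separate contributions of the chlorine and the ring nitrogen, which enter together in compound 4, remain open. Also open, going by these compounds, is whether a saturated ring such as cyclohexyl, or an aromatic ring carrying an amine or a carboxylic acid, on the same carbonyl carbon would read with compound 2 and compound 4 or fall towards compound 1.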